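The source may hold more compounds than are shown below. What is called first, only, known or untested is meant among the compounds shown, and "the series" means these compounds.

Measured so far:
Compound 1 `CC(=O)c1ccc(-c2ccc3c(O)cccc3c2)cc1`: 16%
Compound 2 `O=C(O)c1ccc(-c2ccc3c(O)cccc3c2)cc1`: a limit of the assay, < 10%
Compound 3 `CS(=O)(=O)Nc1ccc(-c2ccc3c(O)cccc3c2)cc1`: 52%

In an assay for binding affinity to 17-beta-hydroxysteroid dehydrogenase type 1 (Homo sapiens), with a stated time of 20 min, tested at 1 uM (a higher number here means more inhibition at the concentration tested (going by the name of the read-out), a lower number less inhibition), compound 3 holds the higher of the two numbers; compound 1 is nearest, and the step of a number 36 percentage points higher from compound 1 to compound 3 (beyond the scatter) lies beyond the scatter. For compound 2 the value is only a limit of the assay, not a number (the limit of < 10% in this assay, at which 1 of the 3 values shown sits). Compound 4 `CNC(=O)c1ccc(-c2ccc3c(O)cccc3c2)cc1` differs from compound 3 in a single place: methylcarbamoyl in place of methanesulfonamido on an aromatic carbon. Going by the values given here, two measured steps bear on this: a number 36 percentage points higher from compound 1 to compound 3 (beyond the scatter) and a number at least 42 percentage points higher from compound 2 to compound 3 (beyond the scatter), both large gains when methanesulfonamido arrived at this carbon. Removing it for methylcarbamoyl is therefore expected to lower the number well beyond the scatter, a number 27 percentage points lower from compound 3 to compound 4 (beyond the scatter). Compound 4 is estimated at 25%, likely between 10% and 45%.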

Compound 4, a percentage reported as inhibition, at one concentration (the size of the read-out at that concentration, not a potency): < 10%
Compound 4: only a limit was reported; the forecaster's own chance of this, stated with the estimate: 15%; middle value at least 15 percentage points from the limit.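

Compound 4 gives < 10% in this assay, and this is a limit of the assay. Having a hydrogen-bond donor and no net charge, as both methanesulfonamido and methylcarbamoyl do, is therefore not enough at this aromatic carbon: the change gives a number at least 42 percentage points lower from compound 3 to compound 4 (beyond the scatter). Against acetyl, the reading is a number at least 6 percentage points lower from compound 1 to compound 4 (that floor lies within the scatter), so methylcarbamoyl shows no gain over it.

Going by these compounds, whether acetamido, which joins the ring through nitrogen as methanesulfonamido does, would keep the higher number remains open. The step between compound 2 and compound 4 cannot be read, because both values are limits: the limit of < 10% in this assay, at which 2 of the 4 values shown sit.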